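A Nitro Group Replaces Chlorine on the Fused Ring

The compounds below may be only part of what the source reports. "The series", "measured", "known", "first", "only" and "open" are said of these compounds alone.

Compound 2 `Nc1ccccc1NC(=O)c1ccc(CSC(=S)N2CCc3cc(Cl)ccc32)cc1` gives 40.1% in a functional assay on HeLa cells (Homo sapiens) for antiproliferative activity, read by CCK-8 assay, with a stated time of 72 h, tested at 2 uM (on this read-out higher numbers stand for a stronger effect at the one concentration tested and lower numbers for a weaker effect), while compound 1 `Nc1ccccc1NC(=O)c1ccc(CSC(=S)N2CCc3ccccc32)cc1` gives 38%, the two numbers lying within the scatter of each other. Compound 3 `Nc1ccccc1NC(=O)c1ccc(CSC(=S)N2CCc3cc([N+](=O)[O-])ccc32)cc1` differs from compound 2 by nitro in place of chloro on an aromatic carbon. For the measured compounds named here, the one measured step that bears on this place on the ring is a number 2.1 percentage points higher from compound 1 to compound 2 (within the scatter), which left the read-out essentially unchanged. Going by the values given here, no measured compound carries a nitro group, so no step beyond the scatter is expected. Compound 3 is therefore estimated at 40%, with a range from 30% to 50%. The expected change is a number 0.1 percentage points lower from compound 2 to compound 3 (within the scatter).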

Compound 3, a percentage reported as inhibition, at one concentration (the size of the read-out at that concentration, not a potency): 32.6%
For compound 3 the middle estimate is 7.4 percentage points above the measured one, and the stated range covers the measured number.
By their numbers in this assay, from the lowest: compounds 3, 1 and 2 (each within the scatter of the next).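

In this assay the nitro group gives a number 7.5 percentage points lower from compound 2 to compound 3 (within the scatter) and a number 5.4 percentage points lower from compound 1 to compound 3 (within the scatter) on the same aromatic carbon that carries chloro in compound 2. Compound 3 therefore cannot be told apart from either neighbour, so this place on the ring has now taken two different groups, one of them with hydrogen-bond acceptors, without a step beyond the scatter. Nothing available explains this result. Going by these compounds, whether an amine, a carboxylic acid or a methoxy group at this place would give a step beyond the scatter stays open.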